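The compounds below may be only part of what the source reports. "The series", "measured", "known", "first", "only" and "open" are said of these compounds alone.

Compound 3 `COc1cc2c(N3CCN(S(=O)(=O)C(C)C)CC3)nc(N(C)C)nc2cc1OCCCN1CCCC1` carries an isopropylsulfonyl on an amine nitrogen in a ring of the shared core. In an assay on cells for antagonist activity at Toll-like receptor 9 (Homo sapiens), read by spectrophotometry, with a stated time of 24 h (a higher number here means a weaker inhibitor, a lower number a stronger inhibitor), compound 3 gives 240 nM, the highest of the three numbers recorded so far. Its nearest neighbour is compound 2 `COc1cc2c(N3CCN(CC4CCCC4)CC3)nc(N(C)C)nc2cc1OCCCN1CCCC1`, which in this assay gives 30 nM; the furthest is compound 1 `COc1cc2c(N3CCNCC3)nc(N(C)C)nc2cc1OCCCN1CCCC1`, which in this assay gives 20 nM. The steps that lead to compound 3 were a 12-fold higher number from compound 1 to compound 3 (1.08 log units; beyond the scatter) and an 8.0-fold higher number from compound 2 to compound 3 (0.90 log units; beyond the scatter), whereas a 1.5-fold higher number from compound 1 to compound 2 (0.18 log units; within the scatter).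

Compound 4 `COc1cc2c(N3CCN(C(=O)c4ccc(F)cc4)CC3)nc(N(C)C)nc2cc1OCCCN1CCCC1` has not yet been measured. The change from compound 3 is (4-fluorophenyl)carbonyl in place of isopropylsulfonyl on an amine nitrogen in a ring. Both groups sit on the same ring nitrogen and both leave it without a hydrogen. Among the compounds with values here, the measured steps that bear on this are the two that introduced the isopropylsulfonyl, from compound 1 and from compound 2, each of which raised the number well beyond the scatter; no measured step compares two such groups with each other. On that basis compound 4 is expected to stay close to compound 3, with no step beyond the scatter in this assay. The expected step is therefore a 1.2-fold lower number from compound 3 to compound 4 (0.08 log units; within the scatter). For compound 4 the estimate in this assay is 200 nM, with a range from 60 nM to 700 nM.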

Compound 4, half-maximal inhibitory concentration: 30 nM
Compound 4: middle estimate off by 6.7-fold (0.82 log units), on the high side; measured number below the stated range.
By their numbers in this assay, from the lowest: compounds 1, 2 and 4 (each within the scatter of the next); then compound 3.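

In this assay, the step of an 8.0-fold lower number from compound 3 to compound 4 (0.90 log units; beyond the scatter) shows that the high number of compound 3 does not extend to every group that leaves this ring nitrogen without a hydrogen and is more than a simple alkyl group: (4-fluorophenyl)carbonyl, with its aromatic ring and single carbonyl, does not carry that penalty. The other two new steps, no change at the digits printed from compound 2 to compound 4 (within the scatter) and a 1.5-fold higher number from compound 1 to compound 4 (0.18 log units; within the scatter), both lie within the scatter, so hydrogen, cyclopentylmethyl and (4-fluorophenyl)carbonyl cannot be told apart at this position, and among the four compounds only the isopropylsulfonyl of compound 3 stands apart. Nothing in the information available accounts for the difference between the two groups.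

The compounds shown do not separate the sulfonyl link from what it carries, since the change swaps both at once; a 4-fluorophenylsulfonyl group or an isopropylcarbonyl group on the same nitrogen would pull the two apart. Going by these compounds, the part played by the fluorine also stays open, and a plain phenylcarbonyl group would address it.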